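Swapping the chlorophenyl ring of compound 2 for a furan

The compounds below may be only part of what the source reports. "The series", "measured", "known", "first", "only" and "open" are said of these compounds alone.

Measured compounds:
- compound 1, `O=C(O)Cc1sc(C(c2ccccc2)c2ccc(F)cc2)nc1-c1ccc(Cl)cc1`: 17 nM
- compound 2, `O=C(O)Cc1sc(C(c2ccc(F)cc2)c2ccc(F)cc2)nc1-c1ccc(Cl)cc1`: 9.7 nM
- compound 3, `O=C(O)Cc1sc(C(c2ccccc2)c2ccccc2)nc1-c1ccc(C(F)(F)F)cc1`: 1100 nM

In an in vitro assay on HEK385-7 cells for displacement of a labelled ligand from prostaglandin D2 receptor 2 (Homo sapiens) (on this read-out lower numbers stand for stronger inhibition and higher numbers for weaker inhibition), compound 2 gives the lowest of the three numbers. Its nearest neighbour is compound 1, and the step of a 1.8-fold lower number from compound 1 to compound 2 (0.24 log units; within the scatter) lies within the scatter, so the two cannot be told apart. For the measured compounds named here, compound 3 stands far away, with a number beyond the scatter from compound 2; it differs from compound 2 in two places, so its value alone shows only that this pair of changes costs a great deal.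

The new compound is compound 4, `O=C(O)Cc1sc(C(c2ccc(F)cc2)c2ccc(F)cc2)nc1-c1ccco1`. It differs from compound 2 in one place: furan-2-yl in place of 4-chlorophenyl on an aromatic carbon. Going by the values given here, no measured step touches this ring: the one step on record concerns a fluoro on a different ring, and it was flat. The ring that leaves carries a chlorine and that at the same position a trifluoromethyl group accompanies a very weak compound 3 suggests this ring matters, yet nothing shows what the furan-2-yl will do.

The estimate for compound 4 in this assay is therefore a cautious loss: a 6.2-fold higher number from compound 2 to compound 4 (0.79 log units; beyond the scatter), giving an expected value of 60 nM, ranging from 12 nM to 300 nM.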

Compound 4, half-maximal inhibitory concentration: 18 nM
Compound 4: middle estimate off by 3.3-fold (0.52 log units), on the high side; low and high end bracket the measured number.
By their numbers in this assay, from the lowest: compounds 2, 1 and 4 (each within the scatter of the next); then compound 3.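

In this assay, a 1.9-fold higher number from compound 2 to compound 4 (0.27 log units; within the scatter) shows that this position, on an aromatic carbon next to the ring nitrogen, does not depend on the 4-chlorophenyl group. A five-membered furan-2-yl ring with an oxygen in it and no chlorine can take the place of the six-membered carbon ring with no difference that can be told apart, so neither the chlorine nor the six-membered ring is shown to be required here. The data give no explanation of why these two different rings cannot be told apart in this assay.

As far as these compounds go, it stays open whether the furan oxygen plays any part, which a thiophen-2-yl group or a plain phenyl ring at the same position on the core of compound 2 could help to test. For the compounds shown here, it also stays open how far the position accepts other groups, such as a 4-trifluoromethylphenyl ring as the only change from compound 2, which would show what that group does here without the second change carried by compound 3.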